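Changing the Benzyl Group on Sulfur

A few compounds are considered here, and "the series" means these few. Any claim that something is new, unique, unknown or untested is made for them only; others in the source may bear on it.

In a functional assay on BGC-823 cells (Homo sapiens) for antiproliferative activity, read by MTT assay, with a stated time of 24 h (a higher number here means a weaker inhibitor, a lower number a stronger inhibitor), compound 2 (`Fc1cccc(F)c1CSc1nnc(-c2ccc3c(c2)OCCO3)n1-c1ccccc1`) gives 84200 nM and compound 1 (`Clc1cccc(CSc2nnc(-c3ccc4c(c3)OCCO4)n2-c2ccccc2)c1`) gives 51200 nM, so the two lie within the scatter of each other. Compound 3 (`Brc1ccc(CSc2nnc(-c3ccc4c(c3)OCCO4)n2-c2ccccc2)cc1`) differs from compound 2 as follows: 4-bromophenyl in place of 2,6-difluorophenyl on a saturated chain carbon bound to a sulfur. In words, 4-bromophenyl stands in place of 2,6-difluorophenyl on a saturated chain carbon bound to a sulfur. For the measured compounds named here, the only measured step bearing on this place is a 1.6-fold higher number from compound 1 to compound 2 (0.22 log units; within the scatter), so no step beyond the scatter is expected in this assay. The expected step is a 1.4-fold lower number from compound 2 to compound 3 (0.15 log units; within the scatter). Compound 3 is estimated at 60000 nM, with an expected range of 25000 nM to 130000 nM.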

Compound 3, half-maximal inhibitory concentration: 33800 nM
Compound 3: middle estimate off by 1.8-fold (0.25 log units), on the high side; the measured number falls inside the stated range.
By their numbers in this assay, from the lowest: compounds 3, 1 and 2 (each within the scatter of the next, the first and the last beyond it).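

In this assay this position now gives a step beyond the scatter, which the earlier pair did not: 4-bromophenyl in place of 2,6-difluorophenyl gives a 2.5-fold lower number from compound 2 to compound 3 (0.40 log units; beyond the scatter) and the change is modest. Set against the 3-chlorophenyl of compound 1, the same 4-bromophenyl gives a 1.5-fold lower number from compound 1 to compound 3 (0.18 log units; within the scatter) and stays within the scatter, so those two groups cannot be told apart here. No evidence at hand bears on this step. On these data alone, whether an amine or a carboxylic acid on the phenyl ring, or a longer chain in place of the benzyl carbon, would shift the number further remains open.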